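Benzylation of a free hydroxy: working notes on the series

The compounds below may be only part of what the source reports. "The series", "measured", "known", "first", "only" and "open" are said of these compounds alone.

Measured so far in a functional assay on KB cells (Homo sapiens) for inhibition, with a stated time of 72 h; on this read-out higher numbers stand for weaker inhibition and lower numbers for stronger inhibition: compound 1, `CC(=O)Oc1cc2oc(-c3ccccc3)cc(=O)c2c(O)c1OC(C)=O`, gives 12700 nM; compound 2, `CC(=O)Oc1cc2oc(-c3ccccc3)cc(=O)c2c(OCc2ccccc2)c1OC(C)=O`, gives 11300 nM; compound 3, `O=c1cc(-c2ccccc2)oc2cc(O)c(OCc3ccccc3)c(O)c12`, gives 4300 nM.

The change from compound 1 to compound 2 is benzyl in place of hydrogen on an oxygen on an aromatic ring. Its effect was a 1.1-fold lower number from compound 1 to compound 2 (0.05 log units; within the scatter). Compound 3 holds the lowest number of the three, and its gaps to compound 2 and to compound 1 both lie beyond the scatter. The difference between the core of compound 3 and the core of compound 1 is not broken down here.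

Compound 4, `O=c1cc(-c2ccccc2)oc2cc(O)c(OCc3ccccc3)c(OCc3ccccc3)c12`, is still to be measured in this assay. It differs from compound 3 by benzyl in place of hydrogen on an oxygen on an aromatic ring, the same change as from compound 1 to compound 2, made at a place described in the same terms. Among the compounds with values here, for compound 4 the expected step is a 1.0-fold lower number from compound 3 to compound 4 (0.01 log units; within the scatter), estimated small because a 1.1-fold lower number from compound 1 to compound 2 (0.05 log units; within the scatter) stayed within the scatter, though only one such pair is known. Compound 4 is accordingly expected to give about 4200 nM in this assay, likely between 1600 nM and 11000 nM.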

Compound 4, half-maximal inhibitory concentration: > 100000 nM
Compound 4: only a limit was reported; the forecaster's own chance of this, stated with the estimate: 3%; at least 23-fold (1.37 log units) between middle value and limit.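

In this assay, benzyl in place of hydrogen on an oxygen on an aromatic ring did not behave alike on the two cores: the same change on two cores in this assay, a 1.1-fold lower number (0.05 log units; within the scatter) from compound 1 to compound 2 and an at least 23-fold higher number (1.36 log units; beyond the scatter) from compound 3 to compound 4, at least 26-fold (1.41 log units) apart, beyond the scatter of two such steps. Compound 4 gives > 100000 nM, which is a limit of the assay and not a number: the limit of > 100000 nM in this assay, at which 1 of the 4 values shown sits. Going by these compounds, the change therefore gave an at least 23-fold higher number from compound 3 to compound 4 (1.36 log units; beyond the scatter), a step whose full size stays unknown, and these two pairs show that the outcome of this change cannot be carried from the core of compound 1 to the core of compound 3, though they do not show which difference between the cores matters or how far this holds beyond these compounds.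

The compounds shown leave open whether a smaller ether, such as methoxy, in place of benzyloxy would give the same outcome on the core of compound 3. They also leave open whether an amine or a carboxylic acid on the benzyl ring would change the reading there.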